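Amide variation on a shared sulfonylpiperidine core

A few compounds are considered here, and "the series" means these few. Any claim that something is new, unique, unknown or untested is made for them only; others in the source may bear on it.

Measured compounds:
compound 1 `CCCS(=O)(=O)N1CCC(CNC(=O)c2ccc(F)cc2C(F)(F)F)(C(=O)N2CCOCC2)CC1`: 67.8 nM
compound 2 `CCCS(=O)(=O)N1CCC(CNC(=O)c2ccc(Cl)cc2Cl)(C(=O)NCC)CC1`: 517 nM

In an assay on isolated protein for inhibition of sodium- and chloride-dependent glycine transporter 1 (Homo sapiens) (a higher number here means a weaker inhibitor, a lower number a stronger inhibitor), compound 2 gives 517 nM, the higher of the two numbers, while compound 1 gives 67.8 nM; the gap between them lies beyond the scatter. Compound 3 `CCCS(=O)(=O)N1CCC(CNC(=O)c2ccc(Cl)cc2Cl)(C(=O)N2CC(N)C2)CC1` differs from compound 2 by 3-aminoazetidin-1-yl in place of ethylamino on a carbonyl carbon. Within the data shown here, no measured pair shows this exact change, so the expectation rests on the comparison with compound 1 alone. Compound 3 is expected to show a modest move toward a lower number, about a 2.1-fold lower number from compound 2 to compound 3 (0.32 log units; beyond the scatter). The value of compound 3 in this assay is estimated at 250 nM, within a range from 60 nM to 1000 nM.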

Compound 3, half-maximal inhibitory concentration: 109 nM
Compound 3: middle estimate off by 2.3-fold (0.36 log units), on the high side; measured number inside the range.
By their numbers in this assay, from the lowest: compounds 1 and 3 (each within the scatter of the next); then compound 2.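

Among these compounds, changing the group on the carbonyl carbon alters the result in this assay, and this is the first comparison in which nothing else differs: a 4.7-fold lower number from compound 2 to compound 3 (0.68 log units; beyond the scatter), with 3-aminoazetidin-1-yl in place of ethylamino. Among the compounds shown here, the step therefore belongs to this one change, which the gap between the earlier compounds could not show. No measurement here explains why the number falls.

As far as these compounds go, it remains open whether the ring or its amine carries the step. An unsubstituted azetidin-1-yl, a 3-hydroxyazetidin-1-yl or an open 2-aminoethylamino chain would separate these.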